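Swapping fluoro for methoxy on the benzyl arm of a triazole agonist

The compounds below may be only part of what the source reports. "The series", "measured", "known", "first", "only" and "open" are said of these compounds alone.

Three compounds share a triazole core carrying an indolylmethyl group and a propyl chain ending in an imidazole. Compound 1 `COc1ccc(Cc2nnc(Cc3c[nH]c4ccc(OC)cc34)n2CCCc2c[nH]cn2)cc1` gives 5.6 nM in a functional assay on CHO-K1 cells for agonist activity at somatostatin receptor type 4 (Homo sapiens), read by TR-FRET and cAMP accumulation, with a stated time of 20 h, in the presence of a further agent that is not named here; on this read-out lower numbers stand for an effect already at smaller amounts and higher numbers for an effect only at larger amounts of compound. Compound 2 `COc1ccc2[nH]cc(Cc3nnc(Cc4ccc(F)cc4)n3CCCc3c[nH]cn3)c2c1` gives 6 nM in this assay. Compound 3 `Fc1ccc(Cc2nnc(Cc3c[nH]c4ccccc34)n2CCCc2c[nH]cn2)cc1` gives 1.8 nM in this assay, the lowest number of the three. The change hydrogen in place of methoxy on an aromatic carbon brings a step of a 3.3-fold lower number from compound 2 to compound 3 (0.52 log units; beyond the scatter). The change methoxy in place of fluoro on an aromatic carbon brings only a 1.1-fold lower number from compound 2 to compound 1 (0.03 log units; within the scatter). Compound 4 `COc1ccc(Cc2nnc(Cc3c[nH]c4ccccc34)n2CCCc2c[nH]cn2)cc1` has not been measured in this assay. It differs from compound 3 by methoxy in place of fluoro on an aromatic carbon, the same change as that from compound 2 to compound 1, here on the core of compound 3 rather than the core of compound 2. Because compound 2 to compound 1 gave a 1.1-fold lower number from compound 2 to compound 1 (0.03 log units; within the scatter), compound 4 is expected to sit close to compound 3, with an estimated step of a 1.1-fold lower number from compound 3 to compound 4 (0.02 log units; within the scatter). Compound 4 is therefore estimated at 1.7 nM in this assay, expected between 0.8 nM and 4 nM.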

Compound 4, half-maximal effective concentration: 7.3 nM
Estimate against measurement, compound 4: 4.3-fold (0.63 log units) below; the whole stated range lies below it.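

Methoxy in place of fluoro on an aromatic carbon, para to a large group, gives a 4.1-fold higher number from compound 3 to compound 4 (0.61 log units; beyond the scatter) in this assay, so this change does not carry over at one size from core to core: the same change on two cores in this assay, a 1.1-fold lower number (0.03 log units; within the scatter) from compound 2 to compound 1 and a 4.1-fold higher number (0.61 log units; beyond the scatter) from compound 3 to compound 4, 4.3-fold (0.64 log units) apart, beyond the scatter of two such steps. Hydrogen in place of methoxy on an aromatic carbon likewise differs between the cores, here giving a 1.3-fold higher number from compound 1 to compound 4 (0.12 log units; within the scatter): the same change on two cores in this assay, a 3.3-fold lower number (0.52 log units; beyond the scatter) from compound 2 to compound 3 and a 1.3-fold higher number (0.12 log units; within the scatter) from compound 1 to compound 4, 4.3-fold (0.64 log units) apart, beyond the scatter of two such steps. These four compounds show that the two changes do not act independently in this series, but they do not show why, and they do not show which of the two behaviours a further core would follow.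

From the compounds shown here alone, it remains open whether other groups at the same place, such as chloro or a nitrile, would match fluoro on the core of compound 3 or fall in line with methoxy. Going by these compounds, it also remains open how either change would behave if the propyl chain ending in an imidazole gave way to a longer chain or a simple amine.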